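A few compounds are considered here, and "the series" means these few. Any claim that something is new, unique, unknown or untested is made for them only; others in the source may bear on it.

Measured compounds:
- compound 1, `Cc1ccc(S(=O)(=O)N(Cc2nnc(Cc3ccccc3Cl)o2)c2cccc(Cl)c2C)cc1`: 398 nM
- compound 2, `COc1ccc(Nc2nnc(CN(c3cccc(Cl)c3C)S(=O)(=O)c3ccc(C)cc3)o2)cc1`: 79.4 nM

In a functional assay on CHO cells for antagonist activity at prostaglandin E2 receptor EP1 subtype (Homo sapiens), read by FLIPR and calcium flux (on this read-out lower numbers stand for stronger inhibition and higher numbers for weaker inhibition), compound 2 gives the lowest of the two numbers, and its nearest neighbour is compound 1, which is separated from it by a step beyond the scatter: a 5.0-fold lower number from compound 1 to compound 2 (0.70 log units; beyond the scatter). That step replaced a 2-chlorobenzyl group on the shared core with a (4-methoxyphenyl)amino group.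

Compound 3, `COc1ccc(NCc2nnc(CN(c3cccc(Cl)c3C)S(=O)(=O)c3ccc(C)cc3)o2)cc1`, has not yet been measured. It differs from compound 2 in one place: ((4-methoxyphenyl)amino)methyl in place of (4-methoxyphenyl)amino on an aromatic carbon. The group that enters keeps the same aryl ring, the same single donor and the same two acceptors, but places one more carbon between the ring of the core and the nitrogen.

For the measured compounds named here, no measured step tests this insertion directly. Going by the values given here, the only step available, from compound 1 to compound 2, concerns the exchange of the whole arm rather than its length, so it offers no firm guide. Compound 3 is therefore expected to stay in the same region as compound 2, with a step of a 2.5-fold higher number from compound 2 to compound 3 (0.40 log units; beyond the scatter), and an estimated value of 200 nM, within a range from 60 nM to 700 nM.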

Compound 3, inhibition constant: 79.4 nM
For compound 3 the middle estimate is 2.5-fold (0.40 log units) above the measured one; the range from low to high includes it.
By their numbers in this assay, from the lowest: compounds 2 and 3 (each within the scatter of the next); then compound 1.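

In this assay the exchange of (4-methoxyphenyl)amino for ((4-methoxyphenyl)amino)methyl gives no change at the digits printed from compound 2 to compound 3 (within the scatter) and so shows that, at this position on the shared core, the amino nitrogen need not be bound directly to the aromatic carbon for the number to stay within the scatter of compound 2. The comparison with the benzyl-type arm can now also be read with the saturated chain carbon kept in both compounds, and the exchange of 2-chlorophenyl for (4-methoxyphenyl)amino on that carbon gives a 5.0-fold lower number from compound 1 to compound 3 (0.70 log units; beyond the scatter) as a step beyond the scatter, so the gap from compound 1 does not rest on the length of the arm alone. Nothing measured here accounts for either result.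

The compounds shown leave open whether a still longer chain, or an ether oxygen in place of the amino nitrogen, would keep the number in the same region. They also leave open whether the same holds for an arm that carries a pyridine in place of the 4-methoxyphenyl ring.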